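The source may hold more compounds than are shown below. What is called first, only, known or untested is meant among the compounds shown, and "the series" means these compounds.

Measured so far in a functional assay on G-361 cells (Homo sapiens) for antiproliferative activity, with a stated time of 72 h; a lower number here means a stronger inhibitor, a higher number a weaker inhibitor:
compound 1, `OC[C@H]1O[C@@H](n2cnc3c(NCc4ccc(Br)cc4)ncnc32)[C@H](O)[C@@H]1O`, gives > 166000 nM.
compound 2, `COc1cccc(CNc2ncnc3c2ncn3[C@@H]2O[C@H](CO)[C@@H](O)[C@H]2O)c1`, gives "not determined" (no result reported).
compound 3, `OC[C@H]1O[C@@H](n2cnc3c(NCc4ccccc4C(F)(F)F)ncnc32)C(O)C1O`, gives > 166000 nM.

The value of compound 1 is a limit of the assay, not a number. The value of compound 3 is likewise a limit of the assay, not a number. Compound 2 has no result in this assay: no single number is reported for it, so its standing can only be read against the two other values, both of which sit at the limit of > 166000 nM in this assay, at which 2 of the 3 values shown sit. Nothing in the shared core is changed across these three; the differences lie in the substituent on the six-membered aromatic ring of carbon only.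

Compound 4, `OC[C@H]1O[C@@H](n2cnc3c(NCc4cccc(C(F)(F)F)c4)ncnc32)[C@H](O)[C@@H]1O`, is not yet measured. Compared with compound 2 it shows (trifluoromethyl in place of methoxy on an aromatic carbon). Within the data shown here, no step between measured compounds is available, so the size of this change cannot be read from the series itself. With compound 1 and compound 3 both at a limit and compound 2 undetermined, no shift beyond the scatter is expected in this assay, and a reported limit rather than a number is the more probable outcome. Compound 4 is expected to give about 150000 nM, estimated between 40000 nM and 500000 nM.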

Compound 4, half-maximal inhibitory concentration: > 166000 nM
Compound 4 ended at the assay's limit; the forecaster's own chance of this, stated with the estimate: 70%; middle value at least 1.1-fold (0.04 log units) away from the limit.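

In this assay no step can be read from compound 1 to compound 4, since both values are limits of the assay and not numbers: the limit of > 166000 nM in this assay, at which 3 of the 4 values shown sit.

The compounds shown leave open whether any substituent on the six-membered aromatic ring of carbon gives a measurable value in this assay.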